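This account rests on a few compounds, and the source may have more. Where it says the series, first, only, none or still open, it means among the compounds named here.

Measured so far:
- compound 1, `Cc1nc(C(=O)NCc2ccccc2)c(O)c(=O)n1C`: > 100000 nM
- compound 2, `Cn1c(Cc2ccccc2C(F)(F)F)nc(C(=O)NCc2cccnc2)c(O)c1=O`: > 100000 nM
- compound 3, `COc1nc(C(C)c2ccccc2C(F)(F)F)nc(C(=O)NCc2ccccc2)c1O`: > 100000 nM

All three compounds were tested in an ADME assay on HepG2 cells (Homo sapiens) for cytotoxicity, in the presence of a further agent that is not named here; a lower number here means a stronger inhibitor, a higher number a weaker inhibitor. Compound 1 gives > 100000 nM, which is a limit of the assay and not a measured number. Compound 2 gives > 100000 nM, again a limit. Compound 3 gives > 100000 nM, also a limit. Compound 2 therefore stands exactly where the other two stand, at the limit of > 100000 nM in this assay, at which 3 of the 3 values shown sit. Within the data shown here, no step between two measured compounds is available, so nothing here shows how any single structural change moves this read-out.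

Compound 4, `CN(Cc1ccccc1)C(=O)c1nc(Cc2ccccc2C(F)(F)F)n(C)c(=O)c1O`, has not yet been tested. It differs from compound 2 in one place: benzyl(methyl)amino in place of ((pyridin-3-yl)methyl)amino on a carbonyl carbon. With every measured compound sitting at the limit, the expected step that the limit leaves unreadable from compound 2 to compound 4 is none beyond the scatter, and compound 4 is most likely to come back as a limit as well. The estimate for compound 4 in this assay is 150000 nM, with a range from 50000 nM to 500000 nM.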

Compound 4, half-maximal inhibitory concentration: > 100000 nM
Compound 4: no number, only a limit (the forecaster's own chance of this, stated with the estimate: 85%); the middle value is on the limit's open side.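

In this assay compound 2 and compound 4 both stand at a limit and not at a number, so no step between them can be read: the limit of > 100000 nM in this assay, at which 4 of the 4 values shown sit.

The compounds shown leave open what structural change, if any, would bring a measurable value in this assay here.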